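Alkyl variation on the five-membered ring of the shared core

The compounds below may be only part of what the source reports. "The series", "measured", "known", "first", "only" and "open" are said of these compounds alone.

The series is followed in a functional assay on HeLa cells (Homo sapiens) for inhibition, read by MTT assay, with a stated time of 72 h; on this read-out higher numbers stand for weaker inhibition and lower numbers for stronger inhibition. Compound 1 `CC(O)c1cn(Cc2cc(=O)oc3cc(O)ccc23)nn1` carries a 1-hydroxyethyl group on an aromatic carbon; in this assay compound 1 gives > 100000 nM, which is a limit of the assay and not a number. Compound 2 `CC(C)(C)c1cn(Cc2cc(=O)oc3cc(O)ccc23)nn1` carries tert-butyl at that place, and in this assay compound 2 gives 81100 nM. Within the data shown here, the step of an at least 1.2-fold lower number from compound 1 to compound 2 (0.09 log units; that floor lies within the scatter) is the only measured step in the set, and it starts from the limit of > 100000 nM in this assay, at which 1 of the 2 values shown sits. Compound 2 thus stands as the sole number shown, the one other value being a limit.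

Compound 3 `CCCCCCc1cn(Cc2cc(=O)oc3cc(O)ccc23)nn1` differs from compound 2 by hexyl in place of tert-butyl on an aromatic carbon. Among the measured compounds shown here, no measured step pairs two alkyl groups of this kind: the step from compound 1 to compound 2 exchanges a hydroxyl-bearing group for an alkyl group and stays within the scatter, so it gives no guide to the size of a change from one alkyl group to a longer one. For compound 3 no step beyond the scatter is expected, the expected step being a 1.4-fold lower number from compound 2 to compound 3 (0.13 log units; within the scatter). The estimate for compound 3 is 60000 nM, with a range from 20000 nM to 200000 nM.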

Compound 3, half-maximal inhibitory concentration: 59000 nM
The estimate for compound 3 lay 1.0-fold (0.01 log units) above the measured number; measured number inside the range.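

In this assay, among these compounds, the exchange of tert-butyl for hexyl on this aromatic carbon gives the first pair at this position in which both groups are alkyl groups, and it yields a 1.4-fold lower number from compound 2 to compound 3 (0.14 log units; within the scatter); at this position, therefore, the change from tert-butyl to hexyl does not separate the two compounds. Hexyl set against 1-hydroxyethyl at the same place gives an at least 1.6-fold lower number from compound 1 to compound 3 (0.22 log units; that floor lies within the scatter), so this second comparison, like the earlier one with tert-butyl, shows no separation beyond the scatter. That step has only a floor, since the value of compound 1 is a limit of the assay and not a number: the limit of > 100000 nM in this assay, at which 1 of the 3 values shown sits.

Going by these compounds, it remains open whether an amine, a carboxylic acid, a phenyl ring or a chain longer than hexyl at this place would give a step beyond the scatter in this assay. The compounds shown also leave open whether any group on this aromatic carbon can bring the number far from those of compound 2 and compound 3.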